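The source may hold more compounds than are shown below. What is called first, only, known or untested is meant among the compounds shown, and "the series" means these compounds.

Compound 1 `Cc1ccc(C#Cc2cc3cn([C@H]4C[C@H](O)[C@@H](CO)O4)c(=O)nc3o2)cc1`: 510000 nM
Compound 2 `Cc1ccc(CCc2cc3cn([C@H]4C[C@H](O)[C@@H](CO)O4)c(=O)nc3o2)cc1`: > 540000 nM

Among the compounds with values here, in an ADME assay on HEL cells (Homo sapiens) for cytotoxicity, with a stated time of 3 days (a higher number here means that more compound is tolerated, a lower number that less compound is tolerated), compound 1 gives 510000 nM, the only true number so far. The entry for compound 2 is a limit of the assay, not a number. Compound 3 `CCCCCc1ccc(C#Cc2cc3cn([C@H]4C[C@H](O)[C@@H](CO)O4)c(=O)nc3o2)cc1` differs from compound 1 at the far end of the molecule, where methyl becomes pentyl: butyl in place of hydrogen on a saturated chain carbon bound to an aromatic carbon. Within the data shown here, no measured step covers this change. Among the measured compounds shown here, the one measured step, an at least 1.0-fold higher number from compound 1 to compound 2 (0.02 log units; that floor lies within the scatter), alters a different part of the molecule, so it offers only weak guidance. The expected change is a 1.5-fold lower number from compound 1 to compound 3 (0.16 log units; within the scatter), which is no step beyond the scatter. For compound 3 the estimate is 350000 nM, with an expected range of 80000 nM to 600000 nM.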

Compound 3, half-maximal cytotoxic concentration: 110000 nM
Beside the measured number, compound 3's estimate is 3.2-fold (0.50 log units) above it; measured number inside the range.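

In this assay, going from methyl to pentyl at the far end of the molecule gives a 4.6-fold lower number from compound 1 to compound 3 (0.67 log units; beyond the scatter). This shows that a change at this end alone, with the core untouched, can move the number beyond the scatter, towards less compound tolerated. The earlier step, in a different part of the molecule, gave only a limit for compound 2, not a number: the limit of > 540000 nM in this assay, at which 1 of the 3 values shown sits.

Only methyl and pentyl are shown at this place, so the course of the number between them remains open. Propyl, a longer chain such as octyl, or a pentyl chain ending in an amine or a carboxylic acid could show whether chain length alone matters.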